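Trimethoxyphenyl for Chlorophenyl on the Shared Core

The source may hold more compounds than are shown below. What is called first, only, known or untested is meant among the compounds shown, and "the series" means these compounds.

Compound 1, `COc1cc(/C=C/C(=O)c2cccc(-n3cc(-c4ccc(Cl)cc4)[nH]c3=O)c2)cc(OC)c1OC`, in a functional assay on SF-539 cells (Homo sapiens) for inhibition (a lower number here means a stronger inhibitor of growth, a higher number a weaker inhibitor of growth), gives 3490 nM. Compound 2, `O=C(/C=C/c1cccc(O)c1)c1cccc(-n2cc(-c3ccccc3)[nH]c2=O)c1`, in this assay gives 1980 nM. Compound 3, `COc1ccc(-c2cn(-c3cccc(C(=O)/C=C/c4ccc(O)c(OC)c4)c3)c(=O)[nH]2)cc1`, in this assay gives 2250 nM.

Among these three numbers compound 1 has the highest. Its nearest neighbour is compound 3, whose number is lower by an amount that stays within the scatter, and the number of compound 2 also sits within the scatter of compound 1. On the numbers shown, then, the three compounds cannot be separated in this assay.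

The next compound, compound 4, is `COc1cc(/C=C/C(=O)c2cccc(-n3cc(-c4cc(OC)c(OC)c(OC)c4)[nH]c3=O)c2)cc(OC)c1OC`. It differs from compound 1 in one place: 3,4,5-trimethoxyphenyl in place of 4-chlorophenyl on an aromatic carbon. The rest of the shared core, with its trimethoxy chalcone arm, is kept.

Going by the values given here, no step between measured compounds that matches this change is available. The three measured numbers span a range that lies wholly within the scatter, and the groups on that aromatic carbon vary among them without any visible effect beyond it. Compound 4 is therefore expected to stay close to compound 1, with a step from compound 1 to compound 4 of a 1.3-fold lower number from compound 1 to compound 4 (0.13 log units; within the scatter), which is not expected to reach beyond the scatter in either direction. For compound 4 the estimated value in this assay is 2600 nM, with a range from 800 nM to 8500 nM.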

Compound 4, concentration for 50% growth inhibition: 3120 nM
Estimate against measurement, compound 4: 1.2-fold (0.08 log units) below; low and high end bracket the measured number.
By their numbers in this assay, from the lowest: compounds 2, 3, 4 and 1 (each within the scatter of the next).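

Going by these compounds alone, the step of a 1.1-fold lower number from compound 1 to compound 4 (0.05 log units; within the scatter) is the first direct reading of a single change on this aromatic carbon of the five-membered aromatic ring with 2 nitrogen, and it is measured in this assay with the trimethoxy chalcone arm held constant. The entering 3,4,5-trimethoxyphenyl has 12 heavy atoms and 3 hydrogen-bond acceptors, against 7 heavy atoms and 0 hydrogen-bond acceptors for 4-chlorophenyl, yet this assay cannot tell the two compounds apart, so on this one pair these differences in size and acceptor count bring no readable difference in growth inhibition. No measurement shown here offers an explanation for this result.

What the compounds shown leave open is whether any group at this place can move the number beyond the scatter, for example an amine, a carboxylic acid or a longer alkyl chain in place of the aryl ring. They also leave open whether 3,4,5-trimethoxyphenyl would give the same reading on a different arm, such as the hydroxyphenyl arm of compound 2.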